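This account rests on a few compounds, and the source may have more. Where it says the series, first, only, none or still open, it means among the compounds named here.

Compound 1, `O=C(Nc1ccc(Oc2ccnc3[nH]ccc23)cc1)c1cn(-c2ccc(Cl)cc2)c2ccccc2c1=O`, and compound 2, `O=C(Nc1ccc(Oc2ccnc3[nH]ccc23)cc1)c1cn(-c2ccc(Br)cc2F)c2ccccc2c1=O`, share one core and differ only in the group carried on an aromatic nitrogen. In a functional assay on HepG2 cells (Homo sapiens) for inhibition, read by MTT assay, with a stated time of 72 h (a lower number here means a stronger inhibitor, a higher number a weaker inhibitor), compound 1 gives 250 nM, and in the same assay compound 2 gives 790 nM. Of the two numbers shown, compound 2 is the higher, that is the weaker inhibitor, and the change is a 3.2-fold higher number from compound 1 to compound 2 (0.50 log units; beyond the scatter).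

Compound 3, `COc1ccc(-n2cc(C(=O)Nc3ccc(Oc4ccnc5[nH]ccc45)cc3)c(=O)c3ccccc32)cc1`, takes the same core and alters the same position: 4-methoxyphenyl in place of 4-bromo-2-fluorophenyl on an aromatic nitrogen. Among the compounds with values here, the only step measured so far, from compound 1 to compound 2, swaps one halogenated phenyl for another and shows a modest change; no measured step puts a methoxy group at this position, so the step to compound 3 cannot be read off directly. Since compound 1 and compound 2 sit within a modest distance of each other, compound 3 is expected to land near that pair, with the change estimated as a 2.0-fold lower number from compound 2 to compound 3 (0.30 log units; within the scatter). On this basis compound 3 is estimated at 400 nM in this assay, with a likely range from 130 nM to 1300 nM.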

Compound 3, half-maximal inhibitory concentration: 5950 nM
For compound 3 the middle estimate is 15-fold (1.17 log units) below the measured one; measured number outside the range, above it.
By their numbers in this assay, from the lowest: compound 1; then compound 2; then compound 3.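

At this position the substituent on the phenyl ring matters more than the first pair suggested: this assay shows a 3.2-fold higher number from compound 1 to compound 2 (0.50 log units; beyond the scatter) between the two halogenated compounds, but a 7.5-fold higher number from compound 2 to compound 3 (0.88 log units; beyond the scatter) once 4-methoxyphenyl enters, which makes compound 3 the weakest inhibitor of the three. The cleanest comparison is a 24-fold higher number from compound 1 to compound 3 (1.38 log units; beyond the scatter) for a single exchange of methoxy in place of chloro on an aromatic carbon, so a large loss needs no change beyond that one group. No measurement shown here accounts for this difference between the halogenated compounds and the methoxy compound.

Compound 3 differs from compound 1 by losing a chlorine and gaining a methoxy group, so these compounds cannot tell whether the higher number follows from removing the halogen or from adding the methoxy group, a question that a plain phenyl ring with no substituent would help to settle. On these data alone, it also remains open how a methyl group, a trifluoromethyl group or an amine such as dimethylamino would behave on the same ring, and so whether methoxy is an isolated case or part of a wider trend.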